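Swapping a Halogenated Ring for a Methyl-Bearing Ring

This account rests on a few compounds, and the source may have more. Where it says the series, first, only, none or still open, it means among the compounds named here.

Measured compounds:
compound 1 `C=CCn1c(=O)/c(=C\c2ccc(Cl)c(Cl)c2)[nH]c(=O)/c1=C\c1ccccc1OC` gives "not active" (no number reported)
compound 2 `C=CCn1c(=O)/c(=C\c2ccccc2OC)[nH]c(=O)/c1=C\c1ccccc1OC` gives 15700 nM
compound 3 `C=CCn1c(=O)/c(=C\c2ccc(F)c(Br)c2)[nH]c(=O)/c1=C\c1ccccc1OC` gives "not active" (no number reported)

These values come from a functional assay on HL-60 cells (Homo sapiens) for cytotoxicity, read by CCK-8 assay, with a stated time of 72 h; a higher number here means a weaker inhibitor, a lower number a stronger inhibitor. Compound 3 stands without a single number: it was recorded as inactive, and compound 1 shares that outcome. Only compound 2 returned a number in this assay, and even that number is high, so the shared core gives weak inhibitors at best here.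

Compound 4 `C=CCn1c(=O)/c(=C\c2ccc(C)cc2)[nH]c(=O)/c1=C\c1ccccc1OC` differs from compound 3 in one place: 4-methylphenyl in place of 3-bromo-4-fluorophenyl on a double-bonded chain carbon bound to an aromatic carbon. Going by the values given here, no measured step covers this change, so its size is unknown. Given that compound 3 and compound 1 were inactive while compound 2 reached only 15700 nM, any shift in this assay is expected to stay small and the outcome weak. Compound 4 is estimated at 25000 nM, with a range from 8000 nM to 80000 nM, and a real chance of no number at all.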

Compound 4, half-maximal inhibitory concentration: "not active" (no number reported)
No number was reported for compound 4, so the estimate cannot be set against anything.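

Compound 3 and compound 4 were both recorded as not active, without a number, so no step can be read between them, and no evidence bears on this result. On these data alone, whether 4-methylphenyl or 3-bromo-4-fluorophenyl gives the stronger compound stays open.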